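The source may hold more compounds than are shown below. What is called first, only, known or untested is meant among the compounds shown, and "the series" means these compounds.

Measured compounds:
compound 1, `COc1ccc(-c2ccc(CO[C@@H]3COc4nc([N+](=O)[O-])cn4C3)s2)cc1F`: in an ADME assay on Vero cells (Chlorocebus sabaeus) for cytotoxicity, with a stated time of 72 h (a higher number here means a weaker inhibitor, a lower number a stronger inhibitor), compound 1 gives > 128000 nM, which is a limit and not a number.
compound 2, `O=[N+]([O-])c1cn2c(n1)OC[C@@H](OCc1csc(-c3ccc(C(F)(F)F)cc3)n1)C2`: in this assay compound 2 gives > 128000 nM, again a limit rather than a number.

Compound 2 therefore stands where every measured compound here stands: its reading is only a limit, and (the limit of > 128000 nM in this assay, at which 2 of the 2 values shown sit). Within the data shown here, no measured compound gives a true number, and no pair of measured compounds differing in one place exists, so nothing about how a single structural change moves this assay can be read from these data.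

Compound 3, `N#Cc1ccc(-c2nc(CO[C@@H]3COc4nc([N+](=O)[O-])cn4C3)cs2)cc1`, is not yet measured. It differs from compound 2 in one place: cyano in place of trifluoromethyl on an aromatic carbon, in words cyano in place of trifluoromethyl on an aromatic carbon. With both measured compounds sitting at the limit, there is no ground for expecting a move in either direction, and the expected step in this assay is a number no higher from compound 2 to compound 3 (the limit leaves the size open), nothing beyond the usual scatter. Compound 3 is accordingly estimated at 128000 nM in this assay, most probably reported once more as a limit, within a range from 64000 nM to 256000 nM.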

Compound 3, half-maximal inhibitory concentration: > 128000 nM
Compound 3: only a limit was reported; the forecaster's own chance of this, stated with the estimate: 85%; the middle value sits exactly at the limit.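

In this assay compound 3 gives > 128000 nM as a limit and not a number. Among these compounds, compound 2 also reads only as a limit, so no step from compound 2 to compound 3 can be read. The compounds shown leave open what true number any of them would give, and whether cyano in place of trifluoromethyl changes it at all.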